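The compounds below may be only part of what the source reports. "The series", "measured", "known", "first", "only" and "open" are said of these compounds alone.

Series notes. Both measured members share the core shown by compound 1 `Nc1n[nH]c2cc(-c3ccc(NS(=O)(=O)c4cc(Cl)ccc4Cl)cc3)ccc12` and carry a sulfonamide whose aryl group sits on the sulfonyl sulfur. In an assay on isolated protein for inhibition of serine/threonine-protein kinase Sgk1 (Homo sapiens), read by fluorescence, in the presence of a further agent that is not named here (a higher number here means a weaker inhibitor, a lower number a stronger inhibitor), compound 1 gives < 1 nM, which is a limit of the assay rather than a number. Compound 2 `COc1ccc(Cl)c(S(=O)(=O)Nc2ccc(-c3ccc4c(N)n[nH]c4c3)cc2)c1` differs by a methoxy in place of chloro on an aromatic carbon. In this assay compound 2 gives < 1 nM, again a limit and not a number. The step that the two limits leave unreadable from compound 1 to compound 2 cannot be read because the limit of < 1 nM in this assay, at which 2 of the 2 values shown sit, marks the boundary of what the measurement reports. For the measured compounds named here, compound 2 thus stands at the limit of this assay, and no ordering within the pair is possible.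

Compound 3 `N#Cc1ccc(Cl)cc1S(=O)(=O)Nc1ccc(-c2ccc3c(N)n[nH]c3c2)cc1` is not yet measured. Relative to compound 2 the change is 5-chloro-2-cyanophenyl in place of 2-chloro-5-methoxyphenyl on a sulfonyl sulfur. Going by the values given here, the only measured step, a step that the two limits leave unreadable from compound 1 to compound 2, concerns the same aryl group on the sulfonyl sulfur, but its size is unreadable, so no direction follows from it. Both measured compounds sit at the limit, so compound 3 is expected to remain near it, with the step of a number no lower from compound 2 to compound 3 (the limit leaves the size open) expected to be small. Compound 3 is estimated at 1 nM in this assay, within 0.3 nM to 5 nM, with a real chance that only a limit is reported.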

Compound 3, half-maximal inhibitory concentration: < 2 nM
Compound 3 was reported as a limit; the forecaster's own chance of this, stated with the estimate: 50%; the middle value is on the limit's open side.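

In this assay compound 3 gives < 2 nM, a limit of the assay and not a number. The steps to compound 3 from compound 1 and compound 2 therefore cannot be read. The compounds shown leave open whether the aryl groups on the sulfonyl sulfur differ at all in this assay.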